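Thiazolopyrimidine series: hydroxy for cyano at the pendant ring

The source may hold more compounds than are shown below. What is called first, only, known or untested is meant among the compounds shown, and "the series" means these compounds.

Compound 3 `N#Cc1cccc(-c2nc(N)c3nc(-c4ccccc4)sc3n2)c1` gives 247 nM in an assay on CHO cells for displacement of a labelled ligand from adenosine receptor A3 (Homo sapiens), read by scintillation counting, with a stated time of 3 h (on this read-out higher numbers stand for weaker inhibition and lower numbers for stronger inhibition), the highest number among the three measured compounds. Compound 1 `Nc1nc(-c2ccccc2)nc2sc(-c3ccccc3)nc12` gives 84 nM in this assay, and compound 2 `COc1ccc(-c2nc(N)c3nc(-c4ccccc4)sc3n2)cc1` gives 46.7 nM. The steps of a 2.9-fold higher number from compound 1 to compound 3 (0.47 log units; beyond the scatter) and a 5.3-fold higher number from compound 2 to compound 3 (0.72 log units; beyond the scatter) both run beyond the scatter, while a 1.8-fold lower number from compound 1 to compound 2 (0.25 log units; within the scatter) stays within it.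

Compound 4 `Nc1nc(-c2cccc(O)c2)nc2sc(-c3ccccc3)nc12` carries the change (hydroxy in place of cyano on an aromatic carbon), hydroxy in place of cyano on an aromatic carbon. Within the data shown here, no measured step puts hydroxy on that ring, so the nearest guide is the removal of cyano, which in reverse is the step from compound 1 to compound 3, and the single substituent change on that ring that lies within the scatter, from compound 1 to compound 2. On this basis the number for compound 4 in this assay is expected to fall back toward the range of compound 1 and compound 2, so that a 2.7-fold lower number from compound 3 to compound 4 (0.44 log units; beyond the scatter) is the expected step. The estimate for compound 4 is 90 nM, within 30 nM to 270 nM.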

Compound 4, inhibition constant: 190 nM
Beside the measured number, compound 4's estimate is 2.1-fold (0.32 log units) below it; the range from low to high includes it.
By their numbers in this assay, from the lowest: compounds 2 and 1 (each within the scatter of the next); then compounds 4 and 3 (each within the scatter of the next).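

With a 1.3-fold lower number from compound 3 to compound 4 (0.11 log units; within the scatter) in this assay hydroxy and cyano on this aromatic carbon cannot be told apart, even though hydroxy brings a hydrogen-bond donor and cyano none. The higher number relative to the unsubstituted phenyl is therefore not tied to cyano alone: hydroxy in place of hydrogen gives a 2.3-fold higher number from compound 1 to compound 4 (0.35 log units; beyond the scatter) in the same direction as a 2.9-fold higher number from compound 1 to compound 3 (0.47 log units; beyond the scatter) and the change from 4-methoxyphenyl to 3-hydroxyphenyl gives a 4.1-fold higher number from compound 2 to compound 4 (0.61 log units; beyond the scatter) as its step. Nothing at hand gives a reason for this.

Open, on these data alone, is whether an amine or a carboxylic acid on the same carbon would stay with compound 3 and compound 4. Equally open, as far as these compounds go, is whether 3-methoxyphenyl would sit with compound 2 or with compound 4, which would separate the effect of the group from that of its place on the ring.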